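Trichlorophenyl ether on the shared core: compound 4

The compounds below may be only part of what the source reports. "The series", "measured", "known", "first", "only" and "open" are said of these compounds alone.

Measured in an assay on isolated protein for inhibition of Dihydrofolate reductase (Homo sapiens), read by spectrophotometry, using NADPH, with stated times of 5 s and 6 min, tested at 5 uM; on this read-out higher numbers stand for a stronger effect at the one concentration tested and lower numbers for a weaker effect:
Compound 1, `NC1=NC2(CCSCC2)N(OCCCOc2ccc(Cl)cc2)C(N)=N1`, gives > 90%; this is a limit of the assay, not a number.
Compound 2, `CC(C)(C)c1ccc(OCCCON2C(N)=NC(N)=NC23CCSCC3)cc1`, gives 85.3%.
Compound 3, `CC(C)(C)c1ccc(OCCCON2C(N)=NC(N)=NC23CCOCC3)cc1`, gives > 90%; this too is a limit of the assay, not a number.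

Compound 1 stands at the limit of > 90% in this assay, at which 2 of the 3 values shown sit, so its own number is not known; among the three, only compound 2 gives a number in this assay. Among the measured compounds shown here, the single measured step, a number at least 4.7 percentage points lower from compound 1 to compound 2 (that floor lies within the scatter), puts tert-butyl in place of chloro on an aromatic carbon and stays within the scatter. Compound 4, `NC1=NC2(CCSCC2)N(OCCCOc2cc(Cl)c(Cl)cc2Cl)C(N)=N1`, differs from compound 1 in the aryl part of the ether: 2,4,5-trichlorophenyl in place of 4-chlorophenyl on an oxygen on a saturated carbon. For the measured compounds named here, no measured step changes the count of chlorines on this ring, so the only guide is that the one change made on this ring, a number at least 4.7 percentage points lower from compound 1 to compound 2 (that floor lies within the scatter), did not leave the scatter, while compound 1 already sits at the limit. Compound 4 is therefore expected to sit at or close to the limit once more. The step expected is a number no higher from compound 1 to compound 4 (the limit leaves the size open), nothing beyond the scatter. The estimate for compound 4 in this assay is 90%, from 80% to 96%.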

Compound 4, a percentage reported as inhibition, at one concentration (the size of the read-out at that concentration, not a potency): 84.4%
For compound 4 the middle estimate is 5.6 percentage points above the measured one, and the stated range covers the measured number.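

In this assay, among the compounds shown here, 2,4,5-trichlorophenyl in place of 4-chlorophenyl on an oxygen on a saturated carbon gives a number at least 5.6 percentage points lower from compound 1 to compound 4 (that floor lies within the scatter), which is the first reading on the count of chlorines on this ring. Compound 4 gives 84.4%, a number rather than a limit, so this ring can carry the two further chlorines with the effect still high at the one concentration tested. The true size of the step cannot be read, because the value for compound 1 is only a limit: the limit of > 90% in this assay, at which 2 of the 4 values shown sit.

The compounds shown do not separate the two added chlorines, so the contribution of each one alone remains open, as does the behaviour of 2,4,5-trichlorophenyl on the core of compound 3. Also open, on these data alone, is what an amine or a carboxylic acid on this aromatic ring would give, and whether a longer chain between the two oxygens would keep the read-out at this level.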